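The source may hold more compounds than are shown below. What is called first, only, known or untested is meant among the compounds shown, and "the series" means these compounds.

Compound 1 `Cc1cc(=O)n(-c2ccccc2C(F)(F)F)nc1C(=O)Nc1ccc(Oc2ncnc3ccsc23)cc1` gives 5550 nM in a functional assay on MCF7 cells (Homo sapiens) for cytotoxicity, read by MTT assay, with a stated time of 72 h; a lower number here means a stronger inhibitor, a higher number a weaker inhibitor.
Compound 2 `Cc1cc(=O)n(-c2ccccc2C(F)(F)F)nc1C(=O)Nc1ccc(Oc2ncnc3ccsc23)c(F)c1` gives 6020 nM in this assay.
Compound 3 `Cc1cc(=O)n(-c2ccccc2C(F)(F)F)nc1C(=O)Nc1ccc(Oc2ncnc3sccc23)cc1` gives in this assay only a limit, > 40000 nM.

Compound 3 thus stands at the weak end of the three compounds, at the limit of > 40000 nM in this assay, at which 1 of the 3 values shown sits, and no number is known for it. The step of an at least 7.2-fold higher number from compound 1 to compound 3 (0.85 log units; beyond the scatter) is the one that brought it there, whereas the step of a 1.1-fold higher number from compound 1 to compound 2 (0.04 log units; within the scatter) left the number unchanged.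

Compound 4 `Cc1cc(=O)n(-c2ccccc2OC(F)(F)F)nc1C(=O)Nc1ccc(Oc2ncnc3sccc23)cc1` differs from compound 3 by trifluoromethoxy in place of trifluoromethyl on an aromatic carbon. Neither measured step touches this part of the molecule: the step from compound 1 to compound 2 concerns a fluoro on another ring, and the step from compound 1 to compound 3 concerns the group on the ether oxygen. Nothing measured therefore speaks for a change beyond the scatter in this assay, and compound 3 itself offers only a limit to start from. The step that the limit leaves unreadable from compound 3 to compound 4 is expected to stay within the scatter. Compound 4 is estimated at 50000 nM, with a range from 20000 nM to 150000 nM, most likely again reported only as a limit.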

Compound 4, half-maximal inhibitory concentration: 11000 nM
Estimate against measurement, compound 4: 4.5-fold (0.66 log units) above; the whole stated range lies above it.
By their numbers in this assay, from the lowest: compounds 1, 2 and 4 (each within the scatter of the next). At a limit, above all of these: compound 3.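

Replacing 2-(trifluoromethyl)phenyl with 2-(trifluoromethoxy)phenyl shows that this place, on an aromatic carbon ortho to a large group, can move the result in this assay, with an at least 3.6-fold lower number from compound 3 to compound 4 (0.56 log units; beyond the scatter). Compound 3 stands only at a limit: the limit of > 40000 nM in this assay, at which 1 of the 4 values shown sits. The step is therefore a bound and not a size. The group on the ether oxygen of compound 3 is kept in compound 4, and compound 4 gives a real number of 11000 nM. So that group does not by itself hold a compound at the limit.

Within the data shown here, whether trifluoromethoxy has a like effect with the other group on the ether oxygen, the one in compound 1, remains open. So does how a methoxy group, a chlorine atom or an amine would fare at this same place.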